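The compounds below may be only part of what the source reports. "The series", "measured", "known", "first", "only" and "open" are said of these compounds alone.

Measured so far:
compound 1 `Cc1ccnc(/C(N)=N/NC(=S)N2CCOCC2)c1` gives 12.8%
compound 2 `Cc1ccnc(/C(N)=N/NC(=S)N2CCSCC2)c1` gives 76.8%
compound 3 `N/C(=N\NC(=S)N1CCSCC1)c1ccc(F)cn1` gives 65.7%

All three numbers come from a functional assay on MCF7 cells (Homo sapiens) for cytotoxicity, read by MTT assay, with a stated time of 72 h, tested at 100 uM; on this read-out lower numbers stand for less inhibition of growth and higher numbers for more inhibition of growth at the one concentration tested. Within this small set the one counted change is the exchange of the ring on the thiocarbonyl carbon. The step of a number 64 percentage points lower from compound 2 to compound 1 (beyond the scatter) goes with morpholin-4-yl in place of thiomorpholin-4-yl on a thiocarbonyl carbon; it is large and well beyond the scatter, and it is the only pairing here in which that exchange has been measured. Within the data shown here, compound 3 and compound 2 differ in their cores, and the difference between the two cores is not broken down here; the two numbers show only that compound 3 gives a lower number than compound 2 in this assay, by more than the scatter.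

Compound 4 `N/C(=N\NC(=S)N1CCOCC1)c1ccc(F)cn1` has not yet been measured. It carries morpholin-4-yl in place of thiomorpholin-4-yl on a thiocarbonyl carbon, the same change already seen between compound 2 and compound 1, at a place described in the same words. With a single prior example, the expectation can rest on nothing more than that one step: the estimate for compound 4 in this assay is 12%, within 2% to 35%, because compound 1 fell to 12.8% after the same exchange. That would mean an expected step of a number 53.7 percentage points lower from compound 3 to compound 4 (beyond the scatter), somewhat smaller than the earlier one since compound 3 starts from a lower number than compound 2 did.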

Compound 4, percent growth inhibition at one concentration: 61.5%
Estimate against measurement, compound 4: 49.5 percentage points below; measured number above the stated range.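

In this assay, morpholin-4-yl in place of thiomorpholin-4-yl on a thiocarbonyl carbon gives a number 4.2 percentage points lower from compound 3 to compound 4 (within the scatter), so the exchange does not carry over from one core to the other with a fixed size: the same change on two cores in this assay, a number 64 percentage points lower (beyond the scatter) from compound 2 to compound 1 and a number 4.2 percentage points lower (within the scatter) from compound 3 to compound 4, 59.8 percentage points apart, beyond the scatter of two such steps

For this series, then, the large step seen on the core of compound 2 cannot be treated as a property of the exchange alone, and any reading of the exchange has to be tied to the core that carries it. The two pairs do not show which part of the cores goes with the difference, nor do they give a rule for how the exchange would behave on a third core.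

Open, as far as these compounds go, is whether other rings on the thiocarbonyl carbon, such as piperidin-1-yl or 4-methylpiperazin-1-yl, or an open-chain dimethylamino group, would follow the pattern of the first core, that of the second, or neither. Also open, from the compounds shown here alone, is whether a chloro or a methoxy group on the core in place of the fluoro group would leave the exchange as small as it is on compound 3.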